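Swapping the amine on the thiocarbonyl for a pyrrolidine ring

The compounds below may be only part of what the source reports. "The series", "measured", "known", "first", "only" and "open" are said of these compounds alone.

Among the compounds with values here, in a functional assay on A-375 cells (Homo sapiens) for antiproliferative activity, read by CCK-8 assay, with a stated time of 72 h, tested at 2 uM (a lower number here means a weaker effect, a higher number a stronger effect of the compound at the concentration tested), compound 1 `CCN(Cc1ccncc1)C(=S)SCc1ccc(C(=O)Nc2ccccc2N)cc1` gives 67.2%, while compound 2 `CN(Cc1cccnc1)C(=S)SCc1ccc(C(=O)Nc2ccccc2N)cc1` gives 39.4%, the lower of the two numbers measured so far. Compound 3 `Nc1ccccc1NC(=O)c1ccc(CSC(=S)N2CCCC2)cc1` differs from compound 2 by pyrrolidin-1-yl in place of methyl((pyridin-3-yl)methyl)amino on a thiocarbonyl carbon. Within the data shown here, the only step known at this position is a number 27.8 percentage points lower from compound 1 to compound 2 (beyond the scatter), which shows that changing the groups on this nitrogen can shift the result by a modest amount in either direction. A step of similar size is therefore expected, with no clear direction, giving compound 3 an estimated 45% (range 20% to 72%), which means an expected a number 5.6 percentage points higher from compound 2 to compound 3 (within the scatter).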

Compound 3, a percentage reported as inhibition, at one concentration (the size of the read-out at that concentration, not a potency): 30.2%
Compound 3: middle estimate off by 14.8 percentage points, on the high side, and the stated range covers the measured number.
By their numbers in this assay, from the lowest: compounds 3 and 2 (each within the scatter of the next); then compound 1.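

In this assay, pyrrolidin-1-yl, with no aromatic ring, gives a number 9.2 percentage points lower from compound 2 to compound 3 (within the scatter), so losing the pyridine ring of compound 2 leaves no measurable difference. Against the ethyl((pyridin-4-yl)methyl)amino group, the same ring gives a number 37 percentage points lower from compound 1 to compound 3 (beyond the scatter), so having a pyridine ring on this nitrogen does not by itself go with the higher number; only compound 1 stands apart. No measurement offered here explains this result.

From the compounds shown here alone, compound 1 and compound 2 differ in both the ethyl group and the pyridine attachment, so which of these matters stays open. Going by these compounds, how ethyl((pyridin-3-yl)methyl)amino or a morpholine ring would behave here is also open.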